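A few compounds are considered here, and "the series" means these few. Any claim that something is new, unique, unknown or untested is made for them only; others in the source may bear on it.

Measured in a functional assay on FM3A cells (Mus musculus) for antiproliferative activity, with a stated time of 48 h; a lower number here means a stronger inhibitor, a higher number a weaker inhibitor:
- compound 1 `C=C(Br)C(=O)Nc1ccc(/C=C/C(=O)c2ccc(Cl)c(Cl)c2)cc1`: 3200 nM
- compound 2 `Nc1ccc(/C=C/C(=O)c2ccc(Cl)cc2)cc1`: 178000 nM

Of these two numbers, compound 2 has the higher at 178000 nM, and its gap to compound 1 lies beyond the scatter. The next compound to read is compound 3 `Nc1ccc(/C=C/C(=O)c2ccc(Cl)c(Cl)c2)cc1`, which comes from compound 2 through a single change: chloro in place of hydrogen on an aromatic carbon.

Going by the values given here, no measured pair shows this change on its own. Compound 1 at 3200 nM carries the same chloro pattern as compound 3 but also differs from it elsewhere, so it does not give the size of this step. The change is small, so a modest step in this assay is expected, towards a lower number, and it may not clear the scatter by much. The estimate is a 2.5-fold lower number from compound 2 to compound 3 (0.41 log units; beyond the scatter). For compound 3 the expected value is 70000 nM, with an estimated range of 20000 nM to 180000 nM.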

Compound 3, half-maximal inhibitory concentration: 33000 nM
The estimate for compound 3 lay 2.1-fold (0.33 log units) above the measured number; the range from low to high includes it.
By their numbers in this assay, from the lowest: compound 1; then compound 3; then compound 2.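

In this assay the chloro entering on an aromatic carbon, ortho to a chloro group and meta to a large group, gives a 5.4-fold lower number from compound 2 to compound 3 (0.73 log units; beyond the scatter) with no other change, so this ring position responds to a single added heavy atom. Compound 3 also makes the gap to compound 1 readable as a change in one place: hydrogen in place of (1-bromoethenyl)carbonyl on the nitrogen gives a 10-fold higher number from compound 1 to compound 3 (1.01 log units; beyond the scatter) on the same dichloro background. Both steps lie beyond the scatter, so the ring chloro and the nitrogen substituent each bear on the antiproliferative read-out, but no measurement here gives a reason for either step.

Open, as far as these compounds go, is whether fluoro, bromo, methyl or methoxy at this ring position would give a step like that of chloro. Also open, from the compounds shown here alone, is what part of the nitrogen substituent carries its step, for example whether a plain acryloyl or acetyl group would behave like (1-bromoethenyl)carbonyl, and whether that step would hold with a single ring chloro.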